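Swapping Fluorine for Methyl on the Aromatic Ring

A few compounds are considered here, and "the series" means these few. Any claim that something is new, unique, unknown or untested is made for them only; others in the source may bear on it.

Compound 1 `CC1=C(/C=C/C(=O)/C=C/c2ccccc2)C(C)(C)CCC1` was tested in a functional assay on PC-3 cells (Homo sapiens) for cytotoxicity, read by sulforhodamine B assay, with a stated time of 48 h (a higher number here means a weaker inhibitor, a lower number a stronger inhibitor), and gives 12400 nM. Compound 2 `CC1=C(/C=C/C(=O)/C=C/c2ccc(Cl)cc2)C(C)(C)CCC1` carries a chlorine on the aromatic ring, and in this assay compound 2 gives 9500 nM, so that a 1.3-fold lower number from compound 1 to compound 2 (0.12 log units; within the scatter). Compound 3 `CC1=C(/C=C/C(=O)/C=C/c2ccc(F)cc2)C(C)(C)CCC1` carries a fluorine instead, and in this assay compound 3 gives 8200 nM; the step from the unsubstituted parent reads a 1.5-fold lower number from compound 1 to compound 3 (0.18 log units; within the scatter), and from the chloro compound a 1.2-fold lower number from compound 2 to compound 3 (0.06 log units; within the scatter). Among the compounds with values here, compound 3 thus shows the lowest of the three numbers, but both gaps lie within the usual scatter of such measurements, so no compound can be called stronger than another.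

Compound 4 `CC1=C(/C=C/C(=O)/C=C/c2ccc(C)cc2)C(C)(C)CCC1` differs from compound 3 in one place: methyl in place of fluoro on an aromatic carbon. Within the data shown here, no measured step involves a methyl group, yet all three changes on that aromatic carbon left the number essentially unchanged. The expected step of a 1.1-fold higher number from compound 3 to compound 4 (0.04 log units; within the scatter) is therefore none beyond the scatter. For compound 4 the estimated value in this assay is 9000 nM, with a range from 4500 nM to 18000 nM.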

Compound 4, half-maximal inhibitory concentration: 21500 nM
Compound 4: middle estimate off by 2.4-fold (0.38 log units), on the low side; measured number above the stated range.
By their numbers in this assay, from the lowest: compounds 3, 2, 1 and 4 (each within the scatter of the next, the first and the last beyond it).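

Within the data shown here, this position is less indifferent than the earlier compounds suggested: in this assay, methyl is the first group on this aromatic carbon to open a gap beyond the scatter, against fluoro (a 2.6-fold higher number from compound 3 to compound 4 (0.42 log units; beyond the scatter)) and against chloro (a 2.3-fold higher number from compound 2 to compound 4 (0.35 log units; beyond the scatter)). Against hydrogen, the same group stays within the scatter (a 1.7-fold higher number from compound 1 to compound 4 (0.24 log units; within the scatter)), so compound 4 separates from compound 2 and compound 3 but not from compound 1. Nothing among the data shown explains why methyl parts from the two halogens here.

Going by these compounds, with only hydrogen, fluoro, chloro and methyl at this place, it remains open how an amine, a carboxylic acid or a longer chain such as propyl would read in this assay. On these data alone, whether the same swaps would give similar steps on other carbons of this ring also remains open.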